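From a 2-chlorophenyl to a 4-bromophenyl group

The compounds below may be only part of what the source reports. "The series", "measured", "known", "first", "only" and "open" are said of these compounds alone.

In an ADME assay on NHDF cells (Homo sapiens) for cytotoxicity, read by MTT assay, with a stated time of 72 h (on this read-out lower numbers stand for stronger inhibition and higher numbers for weaker inhibition), compound 1 `COc1cccc(/C=C2\CCC/C(=C\c3cccc(OC)c3OC)C2=O)c1` gives 16400 nM as its reading, compound 2 `COc1ccc(/C=C2\CCC/C(=C\c3cccc(OC)c3OC)C2=O)cc1` gives 43500 nM as its reading, and compound 3 `COc1ccc(/C=C2\CCC/C(=C\c3ccccc3Cl)C2=O)cc1OC` gives 21600 nM as its reading. Compound 3 thus sits within the usual scatter of both other compounds, although those two lie beyond the scatter of each other. Compound 4 `COc1ccc(/C=C2\CCC/C(=C\c3ccc(Br)cc3)C2=O)cc1OC` carries 4-bromophenyl in place of 2-chlorophenyl on a double-bonded chain carbon bound to a double-bonded ring carbon, a change that counts as 4-bromophenyl in place of 2-chlorophenyl on a double-bonded chain carbon bound to a double-bonded ring carbon in all. Among the measured compounds shown here, only one measured step bears on this, and only indirectly: a 2.7-fold higher number from compound 1 to compound 2 (0.42 log units; beyond the scatter) is a modest change of one aryl group at the same place, but with different groups. For the measured compounds named here, no measured step exchanges one halogen for another. A small move toward a higher number is therefore expected, and the estimated step, a 1.3-fold higher number from compound 3 to compound 4 (0.11 log units; within the scatter), stays within the scatter. For compound 4 the estimated value is 28000 nM, with an expected range from 12000 nM to 60000 nM in this measurement.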

Compound 4, half-maximal inhibitory concentration: 13100 nM
The estimate for compound 4 lay 2.1-fold (0.33 log units) above the measured number, within the range that was stated.
By their numbers in this assay, from the lowest: compounds 4, 1, 3 and 2 (each within the scatter of the next, the first and the last beyond it).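

In this assay, putting 4-bromophenyl in place of 2-chlorophenyl on a double-bonded chain carbon bound to a double-bonded ring carbon gives a 1.6-fold lower number from compound 3 to compound 4 (0.22 log units; within the scatter), so this exchange of one halogen-bearing aryl group for another stays within the scatter. The one earlier step at such a place, a 2.7-fold higher number from compound 1 to compound 2 (0.42 log units; beyond the scatter), lay beyond the scatter, so among the compounds shown this place does not respond alike to every exchange of aryl groups. No measurement given here accounts for either step.

The step from 2-chlorophenyl to 4-bromophenyl alters the halogen and where it sits together, so the part played by each remains unresolved. Also open, on these data alone, is how the reading would respond to an amine or a carboxylic acid on this aryl group, or to a longer chain in its place.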